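An aromatic ring replaces the side group of compound 1

The source may report more compounds than this note shows. Statements on the series, on what has been measured and on what is new or still open speak of the compounds shown alone.

Compound 1 `Cc1cc(C)c(CN2CCc3c(Cl)cc([C@@H](CO)[C@@H]4CCOC4)c(Cl)c3C2=O)c(=O)[nH]1` is the starting point. In a functional assay on KARPAS-422 cells (Homo sapiens) for antiproliferative activity, read by resazurin assay, with a stated time of 72 h (on this read-out lower numbers stand for stronger inhibition and higher numbers for weaker inhibition), compound 1 gives 3950 nM. Compound 2 `Cc1cc(C)c(CN2CCc3c(Cl)cc(C(CO)C4CCOC4)c(Cl)c3C2=O)c(=O)[nH]1` has the same atoms in the same connections, and in this assay compound 2 gives 1040 nM; 17 nM (2 entries). For the measured compounds named here, both of those entries are lower numbers than the one for compound 1, which therefore sits at the weak end of the little that has been measured. Two cautions apply when reading this pair: the several entries of compound 2 in this assay, 1040 nM; 17 nM (2 entries), and (the fact that one of compounds 1 and 2 is drawn with a defined configuration and the other without, at the place where they differ).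

Compound 3 `Cc1cc(C)c(CN2CCc3c(Cl)cc(-c4c(C)noc4C)c(Cl)c3C2=O)c(=O)[nH]1` keeps the core of compound 1 and changes one place: a group of 7 heavy atoms (5 carbon, 1 nitrogen, 1 oxygen; one five-membered aromatic ring with 2 hetero atoms) in place of a group of 8 heavy atoms (6 carbon, 2 oxygen; one five-membered non-aromatic ring with 1 hetero atom), on an aromatic carbon. Going by the values given here, no measured pair shows what such an exchange does, so what follows is a judgement with wide margins. The expected change is a 13-fold lower number from compound 1 to compound 3 (1.12 log units; beyond the scatter), towards stronger inhibition in this assay. That direction rests only on compound 1, at 3950 nM, having the highest number seen so far, which leaves more room to fall than to rise. For compound 3 the estimated value is 300 nM, with an expected range from 40 nM to 2000 nM.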

Compound 3, half-maximal inhibitory concentration: 23 nM
Estimate against measurement, compound 3: 13-fold (1.12 log units) above; the measured number lies below the stated range.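

Compound 3 is the first of these compounds to carry a different kind of group on this aromatic carbon, and placing 3,5-dimethyl-1,2-oxazol-4-yl there in exchange for the side group with the non-aromatic ring gives a 170-fold lower number from compound 1 to compound 3 (2.23 log units; beyond the scatter) in this assay. The entering group has no hydrogen-bond donor and no defined stereocentre, so neither feature is required in the group at this place for a low number in this assay. Compound 3 at 23 nM falls within the span of the entries of compound 2, 1040 nM; 17 nM (2 entries), so the size of the step depends heavily on compound 1 as the reference, and that reference carries its own uncertainty: the fact that one of compounds 1 and 2 is drawn with a defined configuration and the other without, at the place where they differ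

The compounds shown leave open whether the low number of compound 3 depends on the aromatic ring itself or on its two methyl groups, a question that a plain phenyl ring or an unsubstituted 1,2-oxazol-4-yl group at the same carbon would address. They also leave open how this carbon responds to a group of a quite different kind, such as a carboxylic acid or a morpholine ring.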